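Adding nitro to compound 3: working notes

This account rests on a few compounds, and the source may have more. Where it says the series, first, only, none or still open, it means among the compounds named here.

- compound 1 (`O=C(CCCCC1CCSS1)NO`) gives 10.4%
- compound 2 (`O=C(CCCCC(S)CCS)NO`) gives 5.96%
- compound 3 (`O=C(CCCCC1CCSS1)Nc1cccc(C(F)(F)F)c1`) gives "not active" (no number reported)

All three results come from a functional assay on Bel-7402 cells (Homo sapiens) for inhibition, read by MTT assay, with a stated time of 24 h, tested at 0.1 ug/mL (on this read-out lower numbers stand for less inhibition of growth and higher numbers for more inhibition of growth at the one concentration tested), and were obtained at the one concentration tested. Compound 1 and compound 2 lie within the usual scatter of each other. Compound 3 has no number, only a report of no activity, so its distance from the other two cannot be stated on this scale.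

Compound 4 (`O=C(CCCCC1CCSS1)Nc1ccc([N+](=O)[O-])c(C(F)(F)F)c1`) has not yet been measured. The structural change is nitro in place of hydrogen on an aromatic carbon (nitro in place of hydrogen on an aromatic carbon, ortho to a trifluoromethyl group and para to a large group). Within the data shown here, no measured step shows the effect of such a change. A step in this assay of no clear direction and no size beyond the scatter is therefore expected, starting from compound 3 with its result of "not active" (no number reported) as the nearest reference, and a further report without a number remains quite possible. For compound 4 the estimated value is 6% (expected range 0% to 18%).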

Compound 4, percent growth inhibition at one concentration: 5.04%
For compound 4 the middle estimate is 1 percentage points above the measured one; the range from low to high includes it.
By their numbers in this assay, from the lowest: compounds 4, 2 and 1 (each within the scatter of the next).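

Among these compounds, compound 3 has only a report of no activity while compound 4 gives 5.04% and no step between the two can be read. The compounds shown leave open what nitro in place of hydrogen does to growth inhibition on this read-out. No measured evidence bears on this result.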